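Carboxy in place of vinyl: compound 3 to compound 4

The compounds below may be only part of what the source reports. "The series", "measured", "known", "first", "only" and "open" are said of these compounds alone.

Measured in a functional assay on Caco-2 cells (Homo sapiens), read by MTT assay, with a stated time of 48 h; on this read-out higher numbers stand for weaker inhibition and lower numbers for stronger inhibition:
compound 1 `CCN(CC)CCCNC(=O)c1ccc(C(CC)(CC)c2ccc(OCC(O)C(C)(C)C)c(C)c2)n1CC`: 1800 nM
compound 2 `CCn1c(C(=O)NCC(OC)OC)ccc1C(CC)(CC)c1ccc(OCC(O)C(C)(C)C)c(C)c1`: > 50000 nM
compound 3 `C=CCN(C)C(=O)c1ccc(C(CC)(CC)c2ccc(OCC(O)C(C)(C)C)c(C)c2)n1CC`: > 50000 nM

Compound 3 gives > 50000 nM, and this is a limit of the assay, not a number. Compound 2 gives > 50000 nM, which is also a limit. These two compounds share (the limit of > 50000 nM in this assay, at which 2 of the 3 values shown sit). Only compound 1, at 1800 nM, has a true number.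

Compound 4 `CCn1c(C(=O)N(C)CC(=O)O)ccc1C(CC)(CC)c1ccc(OCC(O)C(C)(C)C)c(C)c1` keeps the shared core of compound 3 but carries carboxy in place of vinyl on a saturated chain carbon bound to an amide-type nitrogen. Its allyl(methyl)amino thus becomes (carboxymethyl)(methyl)amino.

Going by the values given here, two measured steps bear on this change: an at least 27-fold higher number from compound 1 to compound 2 (1.44 log units; beyond the scatter) and an at least 27-fold higher number from compound 1 to compound 3 (1.44 log units; beyond the scatter). Both are large, and both remove the (3-(diethylamino)propyl)amino group of compound 1. Compound 4 lacks that group too, so it is expected to stay near the limit, with no readable gain in this assay. The remaining step, a step that the two limits leave unreadable from compound 2 to compound 3, offers no guidance on size or direction.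

The step expected here is a number no higher from compound 3 to compound 4 (the limit leaves the size open). For compound 4 the estimated value is 50000 nM, with an expected range from 15000 nM to 150000 nM.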

Compound 4, half-maximal inhibitory concentration: 31900 nM
For compound 4 the middle estimate is 1.6-fold (0.20 log units) above the measured one; the measured number falls inside the stated range.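

In this assay, compound 4 is the only compound lacking the (3-(diethylamino)propyl)amino group that gives a true number rather than a limit of the assay: the limit of > 50000 nM in this assay, at which 2 of the 4 values shown sit.

Carboxy in place of vinyl, on a saturated chain carbon bound to an amide-type nitrogen, gives an at least 1.5-fold lower number from compound 3 to compound 4 (0.19 log units; that floor lies within the scatter), and (carboxymethyl)(methyl)amino in place of (2,2-dimethoxyethyl)amino gives an at least 1.5-fold lower number from compound 2 to compound 4 (0.19 log units; that floor lies within the scatter), so neither step shows a real gain, although the true size of each remains hidden by the limit. Putting (carboxymethyl)(methyl)amino in place of (3-(diethylamino)propyl)amino on the carbonyl carbon gives an 18-fold higher number from compound 1 to compound 4 (1.25 log units; beyond the scatter), so the carboxy group does not bring back the stronger inhibition seen with the diethylamino chain.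

The compounds shown leave open whether the carboxy group itself matters at this place, which a methyl ester or a primary amide in its position would help to test. They also leave open whether a shorter amine chain on the same carbonyl carbon, such as (2-(dimethylamino)ethyl)amino, would keep the stronger inhibition of compound 1.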